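Adding a methyl to the formyl end of compound 3

The compounds below may be only part of what the source reports. "The series", "measured", "known", "first", "only" and "open" are said of these compounds alone.

Values in a functional assay on HeLa cells (Homo sapiens) for inhibition (on this read-out lower numbers stand for stronger inhibition and higher numbers for weaker inhibition), are as follows
- Compound 1 `Cc1cn(COCCO)c(=O)n(/C=C/C=O)c1=O` gives 20000 nM
- Compound 2 `O=C/C=C/n1c(=O)c(I)cn([C@H]2C[C@H](O)[C@@H](CO)O2)c1=O` gives 15000 nM
- Compound 3 `O=C/C=C/n1c(=O)ccn([C@H]2C[C@H](O)[C@@H](CO)O2)c1=O` gives 15000 nM

Compound 3 stands at 15000 nM level with compound 2, and within the usual scatter of compound 1. The change to compound 4 `CC(=O)/C=C/n1c(=O)ccn([C@H]2C[C@H](O)[C@@H](CO)O2)c1=O` is methyl in place of hydrogen on a carbonyl carbon in words methyl in place of hydrogen on a carbonyl carbon, so formyl becomes acetyl. Going by the values given here, no measured step makes this change. The only one, no change at the digits printed from compound 2 to compound 3 (within the scatter) puts hydrogen in place of iodo on an aromatic carbon, so it offers weak guidance. In this assay no step beyond the scatter is therefore expected, with the estimate being a 1.3-fold higher number from compound 3 to compound 4 (0.12 log units; within the scatter) for this methyl. For compound 4 the estimated value is 20000 nM within an expected range from 8000 nM to 50000 nM on this read-out.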

Compound 4, half-maximal inhibitory concentration: > 100000 nM
Compound 4 gave a limit, no number; the forecaster's own chance of this, stated with the estimate: 15%; middle value at least 5.0-fold (0.69 log units) from the limit.
By their numbers in this assay, from the lowest: compounds 2, 3 and 1 (each within the scatter of the next). At a limit, above all of these: compound 4.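

Going by these compounds alone, the first change at the formyl end of the chain has a clear effect: in this assay, methyl in place of hydrogen on the carbonyl carbon gives an at least 6.6-fold higher number from compound 3 to compound 4 (0.82 log units; beyond the scatter). The earlier step at the iodo position, no change at the digits printed from compound 2 to compound 3 (within the scatter), gave no hint that a single added carbon could matter this much elsewhere. For compound 4, > 100000 nM is a limit of the assay and not a number.

The compounds shown leave open how an ethyl group, a carboxylic acid or an amine on this carbonyl carbon would read in this assay. They also leave open whether any group here could give stronger inhibition than compound 3 at 15000 nM.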